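This account rests on a few compounds, and the source may have more. Where it says the series, first, only, none or still open, it means among the compounds named here.

Measured in an ADME assay on MT4 cells (Homo sapiens) for cytotoxicity, read by MTT assay; a lower number here means that less compound is tolerated, a higher number that more compound is tolerated:
- Compound 1 `Cc1ccccc1C(=O)N(C(=S)OCCN1C(=O)c2ccccc2C1=O)c1ccc(Cl)cc1`: 21000 nM
- Compound 2 `Cc1ccc2c(c1)C(=O)N(CCOC(=S)N(C(=O)c1cccc([N+](=O)[O-])c1)c1ccc(Cl)cc1)C2=O`: > 100000 nM
- Compound 3 `O=C1c2ccccc2C(=O)N1CCOC(=S)N(C(=O)c1ccco1)c1cccc(Cl)c1Cl`: 100000 nM

Compound 2 gives > 100000 nM, which is a limit of the assay and not a number. Of the two true numbers, the higher belongs to compound 3 at 100000 nM. Its nearest neighbour, compound 1 at 21000 nM, lies lower by more than the usual scatter, so compound 3 is the better tolerated of that pair in this assay.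

The next compound to be tested, compound 4 `O=C1c2ccccc2C(=O)N1CCOC(=S)N(C(=O)c1ccco1)c1ccc(Cl)c(Cl)c1`, has the same atoms as compound 3, joined differently: 3,4-dichlorophenyl stands in place of 2,3-dichlorophenyl on an amide-type nitrogen (3,4-dichlorophenyl in place of 2,3-dichlorophenyl on an amide-type nitrogen). Among the compounds with values here, no two measured compounds differ in only one place, so the data give no direct size for such a change. Within the data shown here, the only guide is the spread of the measured values, with compound 1 at 21000 nM as the one clearly lower number. A modest fall in this assay is therefore expected, smaller than the gap between those two numbers and not far beyond the scatter. The estimated change is a 2.0-fold lower number from compound 3 to compound 4 (0.30 log units; within the scatter). Compound 4 is estimated at 50000 nM, with an expected range from 20000 nM to 100000 nM.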

Compound 4, half-maximal cytotoxic concentration: 100000 nM
Beside the measured number, compound 4's estimate is 2.0-fold (0.30 log units) below it; low and high end bracket the measured number.
By their numbers in this assay, from the lowest: compound 1; then compounds 3 and 4 (each within the scatter of the next).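

In this assay, the exchange of 2,3-dichlorophenyl for 3,4-dichlorophenyl on the amide-type nitrogen, whose other neighbours are a carbonyl carbon and a thiocarbonyl carbon, gives no change at the digits printed from compound 3 to compound 4 (within the scatter). Within the data shown here, this is the first pair that differs in only one place, so it gives the first direct reading at this nitrogen: rearranging the two chlorines within the same set of atoms leaves the read-out unmoved on this shared core. The reading comes from the top of the range, where compound 2 gives a limit and not a number, so the flat step may show less than it would lower down: the limit of > 100000 nM in this assay, at which 1 of the 4 values shown sits.

From the compounds shown here alone, what remains open is whether the same rearrangement would also leave the number unmoved on a core that reads lower in this assay, since this one step comes from a single pair. Going by these compounds, it is also open whether a more different group on this nitrogen, such as a phenyl ring carrying a carboxylic acid or an amine, or a longer chain in place of the ring, would change the number at all.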